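A few compounds are considered here, and "the series" means these few. Any claim that something is new, unique, unknown or untested is made for them only; others in the source may bear on it.

Compound 2 `CC(C)[C@H](NC(=O)COc1cccc2ccccc12)C(=O)N[C@@H](CC(=O)O)C(=O)CSc1nncn1C` shares its core with compound 1 `CC(C)[C@H](NC(=O)COc1cccc2ccccc12)C(=O)N[C@@H](CC(=O)O)C(=O)CSc1nc(-c2ccccc2)cs1` and differs from it only in the group attached to the sulfur. In a functional assay on Jurkat cells (Homo sapiens) for inhibition (a higher number here means a weaker inhibitor, a lower number a stronger inhibitor), compound 1 gives no number but only a limit of the assay, > 200000 nM. In this assay compound 2 likewise gives only a limit, > 200000 nM. The step that the two limits leave unreadable from compound 1 to compound 2 is therefore not readable in size. Where compound 2 stands is thus known only as a limit, since (the limit of > 200000 nM in this assay, at which 2 of the 2 values shown sit).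

Compound 3 `CC(C)[C@H](NC(=O)COc1cccc2ccccc12)C(=O)N[C@@H](CC(=O)O)C(=O)CSc1nnnn1C` carries the change (1-methyl-1H-tetrazol-5-yl in place of 4-methyl-4H-1,2,4-triazol-3-yl on a sulfur). For the measured compounds named here, no measured step reads on this change: the single step in this assay was left unreadable by two limits, and every value so far sits at the limit of the assay. From the change itself no step beyond the scatter in this assay is expected, and compound 3 is expected to remain at the limit as well. In this assay compound 3 is expected at 200000 nM, within a range from 50000 nM to 1000000 nM. The step of a number no higher from compound 2 to compound 3 (the limit leaves the size open) that this estimate means is expected to lie within the scatter.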

Compound 3, half-maximal inhibitory concentration: > 200000 nM
Compound 3: a limit, no number; the forecaster's own chance of this, stated with the estimate: 80%; the middle value sits exactly at the limit.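

In this assay compound 3 gives only a limit of the assay, > 200000 nM, and no number. The steps to compound 3 from compound 1 and from compound 2 cannot be read in size. How strongly compound 1, compound 2 and compound 3 inhibit, and whether the group on the sulfur changes that, stays open: the limit of > 200000 nM in this assay, at which 3 of the 3 values shown sit.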